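This account rests on a few compounds, and the source may have more. Where it says the series, first, only, none or still open, it means among the compounds named here.

Values in an ADME assay on the whole organism (Mus musculus, strain CD1) for pharmacokinetics, at a dose of 10 mg/kg by the oral route; on this read-out higher numbers stand for higher exposure at the dose given and lower numbers for lower exposure:
- compound 1 `COc1cc(N2C(=O)C3(CCC3)N(c3ccc(OC4CCN(C)CC4)nc3)C2=S)cnc1C#N`: 6100 ng.h/mL
- compound 2 `CN1CCC(Oc2ccc(N3C(=S)N(c4cnc(C#N)c(C(F)(F)F)c4)C(=O)C34CCC4)cc2)CC1`: 9400 ng.h/mL
- compound 3 `Cc1cc(N2C(=O)C3(CCC3)N(c3ccc(OC4CCNCC4)nc3)C2=S)cnc1C#N`: 7800 ng.h/mL

Compound 2, at 9400 ng.h/mL, lies within the scatter of both compound 1 and compound 3, so the three values do not separate. The next compound is compound 4 `N#Cc1ncc(N2C(=O)C3(CCC3)N(c3ccc(CN4CCNCC4)cc3)C2=S)cc1C(F)(F)F`, with (piperazin-1-yl)methyl in place of (1-methylpiperidin-4-yl)oxy on an aromatic carbon. Going by the values given here, no measured pair differs in one place, so this change has no direct precedent. Compound 3, which has no methyl on its ring nitrogen, gives 7800 ng.h/mL, and this offers only indirect support. The expected change is small and downward, not clearly beyond the scatter: a 1.9-fold lower number from compound 2 to compound 4 (0.27 log units; within the scatter). For compound 4 the estimated value is 5000 ng.h/mL, with an expected range from 1500 ng.h/mL to 14000 ng.h/mL.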

Compound 4, area under the concentration-time curve: 8700 ng.h/mL
Beside the measured number, compound 4's estimate is 1.7-fold (0.24 log units) below it, and the stated range covers the measured number.
By their numbers in this assay, from the lowest: compounds 1, 3, 4 and 2 (each within the scatter of the next).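

On the aromatic carbon para to a large group, in this assay, (piperazin-1-yl)methyl and (1-methylpiperidin-4-yl)oxy do not separate: a 1.1-fold lower number from compound 2 to compound 4 (0.03 log units; within the scatter). This gives the series its first comparison of compounds differing in one place, and the exchange, which also brings in a hydrogen-bond donor, leaves exposure within the scatter. Nothing available accounts for this result.

Still open, on these data alone, is whether (morpholin-4-yl)methyl or a carboxylic acid at this position would also stay within the scatter of compound 2. Also open, as far as these compounds go, is whether the exchange would read the same on the cores of compound 1 and compound 3.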